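Deoxyribose purines: dimethylamino for methylsulfanyl at one carbon

The source may report more compounds than this note shows. Statements on the series, on what has been measured and on what is new or still open speak of the compounds shown alone.

Compound 1 `CSc1nc(SC)c2ncn([C@@H]3C[C@@H](O)[C@H](CO)O3)c2n1`: 167 uM
Compound 2 `CNc1nc(SC)nc2c1ncn2[C@@H]1C[C@@H](O)[C@H](CO)O1`: 81 uM
Compound 3 `Nc1nc(Br)nc2c1ncn2[C@@H]1C[C@@H](O)[C@H](CO)O1`: 1.6 uM

In a functional assay on PHA-Ly cells (Homo sapiens) (a lower number here means a stronger inhibitor, a higher number a weaker inhibitor), compound 1 gives the highest of the three numbers. Compound 2 is nearest, reached by a 2.1-fold lower number from compound 1 to compound 2 (0.31 log units; beyond the scatter). Going by the values given here, compound 3 is furthest; no single-point step links it to compound 1, so only the two values themselves are compared.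

Compound 4 `CSc1nc(N(C)C)c2ncn([C@@H]3C[C@@H](O)[C@H](CO)O3)c2n1` differs from compound 1 by dimethylamino in place of methylsulfanyl on an aromatic carbon. Among the compounds with values here, the one measured step that bears on it is a 2.1-fold lower number from compound 1 to compound 2 (0.31 log units; beyond the scatter), a modest change at the same carbon. A step of similar size in the same direction is therefore expected, though it may not clear the scatter.

Compound 4 is estimated at 95 uM in this assay, within 40 uM to 250 uM. The expected step is a 1.8-fold lower number from compound 1 to compound 4 (0.24 log units; within the scatter).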

Compound 4, concentration for 50% inhibition: 260 uM
Estimate against measurement, compound 4: 2.7-fold (0.44 log units) below, outside the stated range (above it).
By their numbers in this assay, from the lowest: compound 3; then compound 2; then compounds 1 and 4 (each within the scatter of the next).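

In this assay, dimethylamino in place of methylsulfanyl on this aromatic carbon gives a step within the scatter (a 1.6-fold higher number from compound 1 to compound 4 (0.19 log units; within the scatter)), so this change does not repeat the modest step seen with methylamino. Methyl in place of hydrogen on the nitrogen matters more (a 3.2-fold higher number from compound 2 to compound 4 (0.51 log units; beyond the scatter)), which makes the hydrogen on that nitrogen the one single-point difference here with a step beyond the scatter in this direction. No measurement given here explains this difference.

Open, as far as these compounds go, is how a primary amine or an ethylamino chain at this carbon would read on the core of compound 1. Also open, from the compounds shown here alone, is whether a ring amine such as morpholine would read like dimethylamino.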